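The source may hold more compounds than are shown below. What is called first, only, known or untested is meant among the compounds shown, and "the series" means these compounds.

Measured compounds:
- Compound 1, `CC1=CC[C@H](C(C)(C)NC(=S)N/N=C(\C)c2ccccc2)CC1`: in a functional assay on NCI/ADR-RES cells (Homo sapiens) for inhibition, read by sulforhodamine B assay, with a stated time of 48 h (on this read-out lower numbers stand for stronger inhibition of growth and higher numbers for weaker inhibition of growth), compound 1 gives only a limit of the assay, > 100000 nM.
- Compound 2, `COc1ccc(/C(C)=N/NC(=S)NC(C)(C)[C@H]2CC=C(C)CC2)cc1`: in this assay compound 2 gives only a limit of the assay, > 100000 nM.

Compound 2 therefore stands at a limit of this assay and has no number of its own; all that is known is that growth was not fully stopped within the range tested. Among the compounds with values here, the single measured step, a step that the two limits leave unreadable from compound 1 to compound 2, cannot be sized because of the limit of > 100000 nM in this assay, at which 2 of the 2 values shown sit. So nothing measured here tells how a change on the aromatic ring of compound 2 moves the read-out.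

Compound 3, `CC1=CC[C@H](C(C)(C)NC(=S)N/N=C(\C)c2ccc([N+](=O)[O-])cc2)CC1`, differs from compound 2 in one place: nitro in place of methoxy on an aromatic carbon. Within the data shown here, no measured step involves a nitro group, so the size and direction of this change are not known from these data, and no step beyond the scatter can be supported. Compound 3 is therefore expected to sit near the same limit, at about 100000 nM, within 30000 nM to 300000 nM. The step this estimate means is expected to be a number no higher from compound 2 to compound 3 (the limit leaves the size open).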

Compound 3, concentration for total growth inhibition: > 100000 nM
Compound 3: only a limit was reported; the forecaster's own chance of this, stated with the estimate: 75%; the middle value lies on the limit itself.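

Compound 3 stands at a limit of the assay, as compound 1 and compound 2 do, and the steps among these three compounds cannot be read because all their values are limits: (the limit of > 100000 nM in this assay, at which 3 of the 3 values shown sit). The compounds shown leave open whether any change on the aromatic ring moves the read-out at all, and in which direction.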